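The source may hold more compounds than are shown below. What is called first, only, known or untested is meant among the compounds shown, and "the series" means these compounds.

Values measured so far in a functional assay, read by spectrophotometry (on this read-out higher numbers stand for an effect only at larger amounts of compound and lower numbers for an effect already at smaller amounts), are these
compound 1 `COc1ccc(-c2cc(=O)c3ccc(OCCCCN4CCC(C)CC4)cc3o2)cc1` gives 28.1 nM here
compound 2 `COc1ccc(-c2cc(=O)c3ccc(OCCCCCN4CCC(C)CC4)cc3o2)cc1` gives 31.7 nM here
compound 3 `COc1ccc(-c2cc(=O)c3ccc(OCCCCCCN4CCC(CCO)CC4)cc3o2)cc1` gives 34.4 nM here

On these numbers compound 1 cannot be separated from the other two: the step of a 1.1-fold higher number from compound 1 to compound 2 (0.05 log units; within the scatter) and the step of a 1.2-fold higher number from compound 1 to compound 3 (0.09 log units; within the scatter) both stay small.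

Compound 4 `COc1ccc(-c2cc(=O)c3ccc(OCCCCCCCN4CCC(C)CC4)cc3o2)cc1` differs from compound 1 by 3-(4-methylpiperidin-1-yl)propyl in place of 4-methylpiperidin-1-yl on a saturated chain carbon, four bonds along the chain from an oxygen on an aromatic ring with 3-(4-methylpiperidin-1-yl)propyl in place of 4-methylpiperidin-1-yl, on a saturated chain carbon, four bonds along the chain from an oxygen on an aromatic ring.

Closest in kind is the step of a 1.1-fold higher number from compound 1 to compound 2 (0.05 log units; within the scatter) with (4-methylpiperidin-1-yl)methyl entering at that same carbon. The steps to compound 3 bear on the change less directly, since a 2-hydroxyethyl group replaces the methyl on the piperidine there. Even so, the step of a 1.1-fold higher number from compound 2 to compound 3 (0.04 log units; within the scatter) is just as small. For the measured compounds named here, no measured compound carries the 3-(4-methylpiperidin-1-yl)propyl group, so this is an extrapolation and the range is kept wide.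

The step estimated in this assay is a 1.2-fold higher number from compound 1 to compound 4 (0.10 log units; within the scatter) and so no change beyond the scatter is expected. For compound 4 the estimated value is 35 nM with an expected range from 16 nM to 75 nM overall.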

Compound 4, half-maximal effective concentration: 42.6 nM
The estimate for compound 4 lay 1.2-fold (0.09 log units) below the measured number, and the stated range covers the measured number.
By their numbers in this assay, from the lowest: compounds 1, 2, 3 and 4 (each within the scatter of the next).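

In this assay, 3-(4-methylpiperidin-1-yl)propyl in place of 4-methylpiperidin-1-yl, on a saturated chain carbon, four bonds along the chain from an oxygen on an aromatic ring, stays within the scatter (a 1.5-fold higher number from compound 1 to compound 4 (0.18 log units; within the scatter)), so a group of 10 heavy atoms at this position still gives no separable change. The other two steps to compound 4 are also within the scatter: 2-(4-methylpiperidin-1-yl)ethyl in place of 4-methylpiperidin-1-yl gives (a 1.3-fold higher number from compound 2 to compound 4 (0.13 log units; within the scatter)), and (4-methylpiperidin-1-yl)methyl in place of 4-(2-hydroxyethyl)piperidin-1-yl gives (a 1.2-fold higher number from compound 3 to compound 4 (0.09 log units; within the scatter)), which leaves all four compounds unresolved in this assay and the added chain length without a measurable effect across this set. Nothing at hand accounts for this flat response.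

The compounds shown leave open whether the same flat response would hold for a morpholine or a piperazine in place of the 4-methylpiperidine. They also leave open what a propyl chain or a decyl chain between the oxygen and the amine would give in this assay.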